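Replacing 2-fluorophenyl with 5-methylthiophen-2-yl in compound 1

The source may hold more compounds than are shown below. What is called first, only, known or untested is meant among the compounds shown, and "the series" means these compounds.

Of the compounds shown here, three have so far been tested in a functional assay on DU-145 cells (Homo sapiens) for inhibition, read by trypan blue exclusion, with a stated time of 96 h; on this read-out higher numbers stand for weaker inhibition of growth and lower numbers for stronger inhibition of growth. Compound 1 (`Cc1ccc(CS/C(=C/c2ccccc2F)C(=O)c2ccc(Cl)cc2)cc1`) gives 10000 nM and compound 3 (`O=C(/C(=C\c1ccccc1OCc1ccccc1)S(=O)(=O)Cc1ccc(F)cc1)c1ccc(Cl)cc1`) gives 10000 nM, so the two stand level at the lowest number of the set. Compound 2 (`O=C(/C(=C\c1ccccc1F)S(=O)(=O)c1ccc(Br)cc1)c1ccc(Cl)cc1`) gives 25000 nM and sits beyond the scatter above compound 1, which means weaker inhibition of growth.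

Compound 4 (`Cc1ccc(CS/C(=C/c2ccc(C)s2)C(=O)c2ccc(Cl)cc2)cc1`) departs from compound 1 by a single change, with 5-methylthiophen-2-yl in place of 2-fluorophenyl on a double-bonded chain carbon bound to a double-bonded chain carbon. Going by the values given here, no two tested compounds differ in only one place, so this swap has no direct precedent. Compound 1 differs in several places from compound 3, yet compound 3 still reads 10000 nM in this assay, so no large shift is anticipated. The expected outcome is no change beyond the scatter, with a slight lean toward a lower number (a 1.4-fold lower number from compound 1 to compound 4 (0.15 log units; within the scatter)). Compound 4 is therefore expected at 7000 nM, with an estimated range from 2000 nM to 25000 nM when it is measured.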

Compound 4, concentration for 50% growth inhibition: 50000 nM
Compound 4: the middle estimate sits 7.1-fold (0.85 log units) below what was measured; the whole stated range lies below it.
By their numbers in this assay, from the lowest: compounds 1 and 3 (each within the scatter of the next); then compounds 2 and 4 (each within the scatter of the next).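

Putting 5-methylthiophen-2-yl in place of 2-fluorophenyl on a double-bonded chain carbon bound to a double-bonded chain carbon gives, in this assay, a 5.0-fold higher number from compound 1 to compound 4 (0.70 log units; beyond the scatter) and so means weaker inhibition of growth. Going by these compounds alone, this is the first single-place step in the set, and it shows that this position is not indifferent to the group it carries, which the earlier compounds, each differing from the others in several places, could not show. No supporting measurement is at hand to say which part of the change accounts for this step.

The compounds shown leave open whether a thiophen-2-yl without the methyl, or a pyridin-2-yl, on this carbon would read like compound 1 or like compound 4. They also leave open whether the same swap would give a similar step on the sulfonyl-bearing core of compound 2.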